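The source may hold more compounds than are shown below. What is called first, only, known or untested is meant among the compounds shown, and "the series" means these compounds.

Measured in an ADME assay on the whole organism (Rattus norvegicus, strain Sprague-Dawley) for pharmacokinetics, using cassette dosing, at a dose of 1 mg/kg by the oral route; a lower number here means that a smaller share of the oral dose reaches the circulation, a higher number that a larger share of the oral dose reaches the circulation:
- compound 1 `O[C@]1(Cc2cc(-c3cn[nH]c3)on2)CC[C@@H](Cc2ccc(C(F)(F)F)cc2)CC1`: 67.5%
- compound 2 `O=C(c1cc(-c2cn[nH]c2)on1)N1CCC(Cc2ccccc2)CC1`: 0.2%
- compound 3 `O=C(Nc1ccc2[nH]c(=O)oc2c1)C(=O)N1CCN(c2ccc(C(F)(F)F)cc2)CC1`: 24.8%

Compound 3 stands second of the three numbers, beyond the scatter above compound 2 and beyond the scatter below compound 1. The next compound to be measured is compound 4 `COc1ccc(N2CCN(C(=O)C(=O)Nc3ccc4[nH]c(=O)oc4c3)CC2)cc1F`. It keeps the rest of compound 3 and changes in one place: 3-fluoro-4-methoxyphenyl in place of 4-(trifluoromethyl)phenyl on an amine nitrogen in a ring.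

Going by the values given here, no measured pair shows this change or any other single-place change, so the data offer no direct guide to its size. Among the compounds with values here, the only anchor is compound 3 at 24.8%, the closest measured structure. With nothing to argue for a large move, the expectation in this assay is no step beyond the scatter, with a slight lean to a lower number. The estimate amounts to a number 4.8 percentage points lower from compound 3 to compound 4 (within the scatter).

The range is kept wide: compound 2 at 0.2% and compound 1 at 67.5% lie far apart, which shows how much this read-out can vary across these structures. For compound 4 the estimated value is 20%, with an expected range from 8% to 38%.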

Compound 4, oral bioavailability: 0.6%
Compound 4: the middle estimate sits 19.4 percentage points above what was measured, and the stated range ends above it.
By their numbers in this assay, from the lowest: compounds 2 and 4 (each within the scatter of the next); then compound 3; then compound 1.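

In this assay, putting 3-fluoro-4-methoxyphenyl in place of 4-(trifluoromethyl)phenyl on an amine nitrogen in a ring gives a number 24.2 percentage points lower from compound 3 to compound 4 (beyond the scatter), the only single-place step among the compounds shown. This position is therefore not neutral for the read-out: with the rest of compound 3 kept, exchanging this one aromatic group is enough to leave compound 4 at 0.6%. No measurement available here bears on the reason for the step, and the methoxy, the fluorine and the departing trifluoromethyl cannot be told apart as its source.

The compounds shown leave open which part of the entering group carries the step, a question that a phenyl with only the methoxy or only the fluorine on this nitrogen would separate. Also open, on these data alone, is whether a plain phenyl or a phenyl bearing a nitrile stays near compound 3 at 24.8% or falls toward compound 4 at 0.6%, and whether the same exchange gives a step of similar size on a different core.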